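This account rests on a few compounds, and the source may have more. Where it says the series, first, only, none or still open, it means among the compounds named here.

Measured so far in a functional assay on 1321-N1 cells for agonist activity at Free fatty acid receptor 1 (Homo sapiens), read by calcium flux; a higher number here means a larger maximal response, a lower number a smaller maximal response:
compound 1 `O=C(O)CCc1ccc(OCc2ccc(Br)cc2)cc1` — 98%
compound 2 `O=C(O)CCc1ccc(OCc2ccc(Oc3ccccc3)cc2)cc1` — 98%

Compound 2 stands level with compound 1 in this assay; the step of no change at the digits printed from compound 1 to compound 2 (within the scatter) lies within the scatter. Compound 3 `O=C(O)CCc1ccc(OCc2ccc(-c3ccccc3)cc2)cc1` differs from compound 2 by phenyl in place of phenoxy on an aromatic carbon. Among the measured compounds shown here, the only measured step bearing on this change is the one from compound 1 to compound 2, also a change on an aromatic carbon, and it showed no shift. A step of about no change at the digits printed from compound 2 to compound 3 (within the scatter) is therefore expected in this assay, none beyond the scatter in either direction. Compound 3 is expected to give 98%, in the range 86% to 108%.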

Compound 3, largest response reached (reported as efficacy), in percent of the reference or control that the assay uses: 97%
The estimate for compound 3 lay 1 percentage points above the measured number; the measured number falls inside the stated range.
By their numbers in this assay, from the lowest: compounds 3, 1 and 2 (each within the scatter of the next).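

In this assay, phenyl in place of phenoxy gives a number 1 percentage points lower from compound 2 to compound 3 (within the scatter), so the maximal response at this aromatic carbon does not depend on the oxygen of phenoxy. Phenyl in place of bromo gives a number 1 percentage points lower from compound 1 to compound 3 (within the scatter), so bromo, phenoxy and phenyl cannot be told apart by this read-out. No measured information on these groups bears on the result.

As far as these compounds go, whether a methoxy or an amine on this aromatic carbon would keep the response stays open. Also open, from the compounds shown here alone, is whether these three compounds, level in maximal response, differ in potency.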